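Removing a methylene linker: expectation for compound 4

The source may hold more compounds than are shown below. What is called first, only, known or untested is meant among the compounds shown, and "the series" means these compounds.

Among the compounds with values here, compound 3, with the structure `Cc1cc(NCc2ccncc2)n2nc(C)c(-c3ccccc3)c2n1`, is the only member of this small set that returns a number in a physicochemical assay for solubility, read by HPLC, using the shake flask method, measured as kinetic solubility, with a stated time of 2 h, at pH 7.4 (on this read-out higher numbers stand for higher solubility and lower numbers for lower solubility), where compound 3 gives 134000 nM. Compound 1, with the structure `Cc1cc(NCc2ccccn2)n2nc(C)c(-c3ccc(F)cc3)c2n1`, sits at a limit of this assay, and in this assay compound 1 gives < 5000 nM. Compound 2, with the structure `Cc1cc(NCc2ccccn2)n2ncc(-c3ccc(F)cc3)c2n1`, also sits at a limit, and in this assay compound 2 gives < 5000 nM. Within the data shown here, the one measured step, a step that the two limits leave unreadable from compound 1 to compound 2, is hydrogen in place of methyl on an aromatic carbon, and the limit of < 5000 nM in this assay, at which 2 of the 3 values shown sit, leaves its size unreadable. Compound 4, with the structure `Cc1cc(Nc2ccccn2)n2nc(C)c(-c3ccccc3)c2n1`, differs from compound 3 in another place altogether: pyridin-2-yl in place of (pyridin-4-yl)methyl on a nitrogen on an aromatic ring. No measured step bears on this change, so the direction of the step in this assay cannot be drawn from the data shown. The step from compound 3 to compound 4 is estimated at a 4.5-fold lower number from compound 3 to compound 4 (0.65 log units; beyond the scatter), with wide uncertainty. Compound 4 is therefore expected to give about 30000 nM in this assay, within the range 5000 nM to 130000 nM.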

Compound 4, solubility: < 5000 nM
Compound 4: only a limit was reported; the forecaster's own chance of this, stated with the estimate: 25%; middle value at least 6.0-fold (0.77 log units) from the limit.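

Within the data shown here, this change gives the first readable step in the set, since the one earlier step cannot be read: on a nitrogen on an aromatic ring, pyridin-2-yl in place of (pyridin-4-yl)methyl gives an at least 26-fold lower number from compound 3 to compound 4 (1.42 log units; beyond the scatter) in this assay, so this position can carry a large change in the read-out. The value of compound 4 is a limit and not a number. Among these compounds, compound 3 thus remains the only compound with a number in the set: the limit of < 5000 nM in this assay, at which 3 of the 4 values shown sit.

This one change both shortens the group on the nitrogen and replaces pyridin-4-yl with pyridin-2-yl, and the compounds shown do not separate these two parts. Pyridin-4-yl directly on that nitrogen, or a longer chain such as 2-(pyridin-4-yl)ethyl, would bear on that question.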